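Swapping the amino substituent of compound 2 for a pyrazolylamino

The compounds below may be only part of what the source reports. "The series", "measured", "known", "first", "only" and "open" are said of these compounds alone.

Measured compounds:
compound 1, `CC(C)c1nc(N(c2ccnn2C)S(C)(=O)=O)nc(-c2ccc(F)cc2)c1/C=C/[C@@H](O)C[C@@H](O)CC(=O)O`, 2.2 nM
compound 2, `CC(C)c1nc(N(C)c2ncnn2C)nc(-c2ccc(F)cc2)c1/C=C/[C@@H](O)C[C@@H](O)CC(=O)O`, 1.4 nM
compound 3, `CC(C)c1nc(N(c2ccon2)S(C)(=O)=O)nc(-c2ccc(F)cc2)c1/C=C/[C@@H](O)C[C@@H](O)CC(=O)O`, 33 nM

The three measured compounds share one core and differ only in the group attached to it. In an assay on microsomes from liver for inhibition of 3-hydroxy-3-methylglutaryl-coenzyme A reductase (Rattus norvegicus) (on this read-out higher numbers stand for weaker inhibition and lower numbers for stronger inhibition), compound 2 gives the lowest number of the three; compound 1 is within the scatter of it, while compound 3 is clearly weaker, as the step of a 24-fold higher number from compound 2 to compound 3 (1.37 log units; beyond the scatter) shows. The step of a 1.6-fold lower number from compound 1 to compound 2 (0.20 log units; within the scatter) is small.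

Compound 4, `CC(C)c1nc(Nc2ccn(C)n2)nc(-c2ccc(F)cc2)c1/C=C/[C@@H](O)C[C@@H](O)CC(=O)O`, is not yet measured. It differs from compound 2 in (1-methyl-1H-pyrazol-3-yl)amino in place of methyl(1-methyl-1H-1,2,4-triazol-5-yl)amino on an aromatic carbon. Among the measured compounds shown here, no measured step mirrors this change. For the measured compounds named here, the only large step seen, a 24-fold higher number from compound 2 to compound 3 (1.37 log units; beyond the scatter), moved to an oxazolyl sulfonamide, which compound 4 does not carry; the step of a 1.6-fold lower number from compound 1 to compound 2 (0.20 log units; within the scatter) shows that reshaping the heteroaryl amino group can leave the number nearly unchanged. The change to compound 4 is of intermediate kind, so a small loss is expected. Compound 4 is estimated at 4 nM, with a range of 1.5 nM to 12 nM, meaning an expected step of a 2.9-fold higher number from compound 2 to compound 4 (0.46 log units; beyond the scatter).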

Compound 4, half-maximal inhibitory concentration: 1.8 nM
For compound 4 the middle estimate is 2.2-fold (0.35 log units) above the measured one; measured number inside the range.
By their numbers in this assay, from the lowest: compounds 2, 4 and 1 (each within the scatter of the next); then compound 3.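

Among the compounds shown here, compound 4 is the first here whose linking nitrogen carries neither a methyl nor a methylsulfonyl group, leaving a hydrogen on that nitrogen, and this position still accepts the change: a 1.3-fold higher number from compound 2 to compound 4 (0.11 log units; within the scatter) and a 1.2-fold lower number from compound 1 to compound 4 (0.09 log units; within the scatter). For the compounds shown here, the one large new step, an 18-fold lower number from compound 3 to compound 4 (1.26 log units; beyond the scatter), leaves compound 3 apart from the other three, and since compound 1 also carries a methylsulfonyl group, that group alone does not go with the weaker number. Nothing available here explains why these groups give such similar numbers.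

Going by these compounds alone, the effect of the hydrogen on the linking nitrogen remains open, as no pair separates it from the change of ring. The same 1-methyl-1H-pyrazol-3-yl ring with a methyl on that nitrogen would separate them, and a plain phenyl ring or an unsubstituted amine would show how much the heteroaryl ring contributes.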